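Adding a third chlorine to the aryl ether of compound 3

The source may hold more compounds than are shown below. What is called first, only, known or untested is meant among the compounds shown, and "the series" means these compounds.

Three compounds share one core and differ only in the chlorinated phenyl ring at the end of the ether chain. Compound 1 `NC1=NC2(CCSCC2)N(OCCCOc2ccc(Cl)c(Cl)c2)C(N)=N1` gives 88.4% in an assay on isolated protein for inhibition of Dihydrofolate reductase (Homo sapiens), read by spectrophotometry, using NADPH, with stated times of 5 s and 6 min, tested at 5 uM; on this read-out higher numbers stand for a stronger effect at the one concentration tested and lower numbers for a weaker effect. Compound 2 `NC1=NC2(CCSCC2)N(OCCCOc2cccc(Cl)c2)C(N)=N1` gives 88.3% in this assay, and compound 3 `NC1=NC2(CCSCC2)N(OCCCOc2cccc(Cl)c2Cl)C(N)=N1` gives 83.8%. On these numbers compound 3 sits at the low end of the three, but the distance to each neighbour is small: a number 4.6 percentage points lower from compound 1 to compound 3 (within the scatter) and a number 4.5 percentage points lower from compound 2 to compound 3 (within the scatter), just as a number 0.1 percentage points lower from compound 1 to compound 2 (within the scatter). None of the three chlorine patterns can therefore be told apart in this assay.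

Compound 4 `NC1=NC2(CCSCC2)N(OCCCOc2cc(Cl)c(Cl)cc2Cl)C(N)=N1` differs from compound 3 by 2,4,5-trichlorophenyl in place of 2,3-dichlorophenyl on an oxygen on a saturated carbon. All measured steps between chlorine patterns on this ring were within the scatter, so no step beyond the scatter is expected here either, and compound 4 is expected to give 85% in this assay, between 72% and 94%, which is estimated as a number 1.2 percentage points higher from compound 3 to compound 4 (within the scatter).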

Compound 4, a percentage reported as inhibition, at one concentration (the size of the read-out at that concentration, not a potency): 84.4%
For compound 4 the middle estimate is 0.6 percentage points above the measured one; measured number inside the range.
By their numbers in this assay, from the lowest: compounds 3, 4, 2 and 1 (each within the scatter of the next).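

The 2,4,5-trichlorophenyl ring extends the series, yet the read-out in this assay stays within the scatter of the rings before it, with a number 0.6 percentage points higher from compound 3 to compound 4 (within the scatter) and a number 3.9 percentage points lower from compound 2 to compound 4 (within the scatter) as the steps from the 2,3-dichlorophenyl and 3-chlorophenyl rings. Putting chloro in place of hydrogen on an aromatic carbon of the 3,4-dichlorophenyl ring gives a number 4 percentage points lower from compound 1 to compound 4 (within the scatter) and so does not separate the two compounds either. This same change can now be read twice, and the two steps agree: the same change on two cores in this assay, a number 4.5 percentage points lower (within the scatter) from compound 2 to compound 3 and a number 4 percentage points lower (within the scatter) from compound 1 to compound 4, 0.5 percentage points apart, within the scatter of two such steps.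

From the compounds shown here alone, each value comes from a single concentration, so it shows only the size of the effect at that concentration, and whether these rings would give a stronger or weaker effect at any other concentration stays open. Also open, going by these compounds, is how the read-out would respond to an amine or a carboxylic acid on this ring, or to a longer chain before the oxygen.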